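Methyl on an Aromatic Nitrogen and Cytotoxicity in MCF7 Cells

The source may hold more compounds than are shown below. What is called first, only, known or untested is meant among the compounds shown, and "the series" means these compounds.

Compound 1 `COc1ccc2c(c1)c(/C=N\NC(=O)c1cn(C)c3ccccc13)cn2Cc1ccc(Cl)cc1`: 99100 nM
Compound 2 `COc1ccc2c(c1)c(/C=N\NC(=O)c1c[nH]c3ccccc13)cn2Cc1ccc(Cl)cc1`: 8700 nM
Compound 3 `COc1ccc(Cn2cc(/C=N\NC(=O)c3c[nH]c4ccccc34)c3ccc(F)cc32)cc1`: 13100 nM

Of the compounds shown here, three have been measured in a functional assay on MCF7 cells (Homo sapiens) for cytotoxicity; on this read-out higher numbers stand for weaker inhibition and lower numbers for stronger inhibition. Compound 2 gives 8700 nM, and compound 1 gives 99100 nM. The two differ in one place, (methyl in place of hydrogen on an aromatic nitrogen), and this change produced an 11-fold higher number from compound 2 to compound 1 (1.06 log units; beyond the scatter).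

Compound 3 gives 13100 nM in this assay; its value and that of compound 2 lie within the scatter of each other. The difference between the core of compound 3 and the core of compound 2 is not broken down here.

Compound 4 `COc1ccc(Cn2cc(/C=N\NC(=O)c3cn(C)c4ccccc34)c3ccc(F)cc32)cc1` has not yet been measured. It differs from compound 3 by methyl in place of hydrogen on an aromatic nitrogen, the same change seen between compound 2 and compound 1. Resting on compound 3 with 13100 nM and on the step of an 11-fold higher number from compound 2 to compound 1 (1.06 log units; beyond the scatter), compound 4 is expected to show a step of a 7.6-fold higher number from compound 3 to compound 4 (0.88 log units; beyond the scatter). Compound 4 is therefore estimated at 100000 nM in this assay, with a plausible range from 40000 nM to 250000 nM. Since compound 1 already sits near the upper edge of what such assays typically report, there is a fair chance that compound 4 will return only a limit rather than a number.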

Compound 4, half-maximal inhibitory concentration: 22600 nM
The estimate for compound 4 lay 4.4-fold (0.65 log units) above the measured number; the whole stated range lies above it.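

In this assay, the new step for methyl in place of hydrogen on an aromatic nitrogen is a 1.7-fold higher number from compound 3 to compound 4 (0.24 log units; within the scatter). The change therefore did not carry over at one size from one core to the other, and a step read on one core would have been a poor guide to the step on the other: the same change on two cores in this assay, an 11-fold higher number (1.06 log units; beyond the scatter) from compound 2 to compound 1 and a 1.7-fold higher number (0.24 log units; within the scatter) from compound 3 to compound 4, 6.6-fold (0.82 log units) apart, beyond the scatter of two such steps. What this does not show is which feature of the cores sets the size of the step, since the core of compound 2 and the core of compound 3 differ in more than one place and these two pairs cannot separate those differences.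

The compounds shown leave open how an ethyl group, or a longer chain carrying an amine, would read on that aromatic nitrogen on either core. They also leave open whether the same methyl change on a third core would give a step closer to the large one or to the one within the scatter.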